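A few compounds are considered here, and "the series" means these few. Any claim that something is new, unique, unknown or untested is made for them only; others in the source may bear on it.

The measured compounds:
compound 1 `c1cncc(CN[C@H]2C3C4CC5C6C4CC3C6C52)c1`: 508 nM
compound 2 `Fc1cccc(CCCN[C@H]2C3C4CC5C6C4CC3C6C52)c1`: 24.9 nM

In an assay on brain for displacement of a labelled ligand from Sigma non-opioid intracellular receptor 1 (Rattus norvegicus) (on this read-out lower numbers stand for stronger inhibition and higher numbers for weaker inhibition), compound 1 gives 508 nM, the highest of the two numbers recorded so far. Compound 2 gives 24.9 nM, a markedly lower number, and the gap between the two compounds lies well beyond the scatter of this assay. Compound 3 `C1CCC(CN[C@H]2C3C4CC5C6C4CC3C6C52)CC1` has not yet been measured. It differs from compound 1 in one place: cyclohexyl in place of pyridin-3-yl on a saturated chain carbon bound to an amine nitrogen. Among the measured compounds shown here, no measured pair isolates this particular change, so no step for it can be read directly from the numbers in hand. Compound 3 is nevertheless expected to show a step of a 7.3-fold lower number from compound 1 to compound 3 (0.86 log units; beyond the scatter), that is a move toward lower numbers that goes beyond the scatter. The estimate for compound 3 in this assay is 70 nM, with a range from 15 nM to 300 nM.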

Compound 3, inhibition constant: 4 nM
The estimate for compound 3 lay 18-fold (1.24 log units) above the measured number; the whole stated range lies above it.
By their numbers in this assay, from the lowest: compound 3; then compound 2; then compound 1.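

In this assay, replacing pyridin-3-yl with cyclohexyl gives a 130-fold lower number from compound 1 to compound 3 (2.10 log units; beyond the scatter), so this position on a saturated chain carbon bound to an amine nitrogen responds strongly to the identity of the ring it carries, even when the heavy-atom count stays the same. The pyridin-3-yl ring, with its ring nitrogen and hydrogen-bond acceptor, is therefore not needed for a low number here, since the all-carbon, non-aromatic ring reaches a far lower one on the same core. No measurement here bears on why the number fell.

This single change removes the aromatic ring and the ring nitrogen together, so the pair cannot show which of the two matters. A phenyl ring at this place would separate them, while cyclopentyl or a longer chain carrying the cyclohexyl would test how far the low number extends.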